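Amide aryl variation on a shared core: notes

This account rests on a few compounds, and the source may have more. Where it says the series, first, only, none or still open, it means among the compounds named here.

Three compounds share one core and differ only in the aryl group on the carbonyl carbon of the amide. Compound 1 `Cc1nc(C(=O)Nc2ccc(Cl)c(-c3nnc4c(Cl)cccn34)c2)cs1` carries a 2-methyl-1,3-thiazol-4-yl group there. In a functional assay on MCF7 cells (Homo sapiens) for antiproliferative activity, read by MTT assay, with a stated time of 72 h (on this read-out higher numbers stand for weaker inhibition and lower numbers for stronger inhibition), compound 1 gives > 100000 nM, which is a limit of the assay and not a number. Compound 2 `CS(=O)(=O)c1ccc(C(=O)Nc2ccc(Cl)c(-c3nnc4c(Cl)cccn34)c2)cc1` carries a 4-(methylsulfonyl)phenyl group; in this assay compound 2 gives 94200 nM. Compound 3 `O=C(Nc1ccc(Cl)c(-c2nnc3c(Cl)cccn23)c1)c1ccon1` carries a 1,2-oxazol-3-yl group. In this assay compound 3 gives > 100000 nM, again a limit of the assay. The step of an at least 1.0-fold lower number from compound 1 to compound 2 (0.02 log units; that floor lies within the scatter) and the step of an at least 1.0-fold higher number from compound 2 to compound 3 (0.02 log units; that floor lies within the scatter) are both floors within the scatter; the step that the two limits leave unreadable from compound 1 to compound 3 cannot be read because of the limit of > 100000 nM in this assay, at which 2 of the 3 values shown sit. Compound 3 therefore stands at the limit, with no measured value beneath it.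

Compound 4 `O=C(Nc1ccc(Cl)c(-c2nnc3c(Cl)cccn23)c1)c1c(F)cccc1Cl` is not yet measured. The change is 2-chloro-6-fluorophenyl in place of 1,2-oxazol-3-yl on a carbonyl carbon. Within the data shown here, no measured step covers a carbon-only ring with two halogens in this place, and the steps that do exist all sit at or within the scatter near the limit. The expectation is a step of an at least 1.1-fold lower number from compound 3 to compound 4 (0.07 log units; that floor lies within the scatter) that cannot be told from the scatter, with a fair chance that compound 4 also reports only a limit. Compound 4 is estimated at 85000 nM, within 30000 nM to 100000 nM.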

Compound 4, half-maximal inhibitory concentration: > 100000 nM
Compound 4: only a limit was reported; the forecaster's own chance of this, stated with the estimate: 50%; middle value at least 1.1-fold (0.07 log units) away from the limit.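

Adding the carbon-only ring with two halogens, 2-chloro-6-fluorophenyl, extends the range of groups on this carbonyl carbon: a six-membered aromatic ring of carbon only now sits at the limit in this assay, as do the two five-membered aromatic rings of compound 1 and compound 3. Among these compounds, the one numerical comparison the new result allows is the step of an at least 1.0-fold higher number from compound 2 to compound 4 (0.02 log units; that floor lies within the scatter), so this change cannot be separated from the scatter and compound 2 keeps no readable edge over compound 4. The steps to compound 4 from compound 1 and from compound 3 cannot be read, because each has a limit at both ends: the limit of > 100000 nM in this assay, at which 3 of the 4 values shown sit.

Across the aryl groups shown, the series gives no readable structure-activity trend at this position, and it remains open whether any group on this carbonyl carbon can bring a value clearly below the limit. On these data alone, a piperidine amine, a carboxylic acid or a longer alkyl chain in this place would test that question, and the effect of such groups in this assay remains unknown.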